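The source may hold more compounds than are shown below. What is called first, only, known or untested is meant among the compounds shown, and "the series" means these compounds.

Measured in an assay on CHO cells for displacement of a labelled ligand from adenosine receptor A1 (Homo sapiens), read by scintillation counting, with a stated time of 90 min; a lower number here means a stronger inhibitor, a higher number a weaker inhibitor:
compound 1 `Nc1nc(NCc2cccs2)nc2sc(-c3ccco3)nc12` gives 12.5 nM;
compound 2 `Nc1nc(NCc2cccnc2)nc2sc(-c3ccco3)nc12` gives 7.12 nM;
compound 3 `Nc1nc(NCc2ccsc2)nc2sc(-c3ccco3)nc12` gives 8.12 nM.

Compound 3 stands second highest of these three numbers, though all three lie within the scatter of one another. Compound 4 `Nc1nc(NCc2cnccn2)nc2sc(-c3ccco3)nc12` differs from compound 3 by pyrazin-2-yl in place of thiophen-3-yl on a saturated chain carbon bound to a nitrogen on an aromatic ring. Among the measured compounds shown here, the steps that bear on this change are the earlier swaps of one small aromatic ring for another at the same place: a 1.8-fold lower number from compound 1 to compound 2 (0.24 log units; within the scatter), a 1.5-fold lower number from compound 1 to compound 3 (0.19 log units; within the scatter) and a 1.1-fold higher number from compound 2 to compound 3 (0.06 log units; within the scatter), none of them beyond the scatter. Pyrazin-2-yl itself has not been tested, so the expectation rests on those swaps alone. No step beyond the scatter is expected, and the estimated step is a 1.0-fold higher number from compound 3 to compound 4 (0.02 log units; within the scatter). Compound 4 is therefore expected to give about 8.5 nM, within 3.5 nM to 22 nM.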

Compound 4, inhibition constant: 25 nM
The estimate for compound 4 lay 2.9-fold (0.47 log units) below the measured number; measured number outside the range, above it.
By their numbers in this assay, from the lowest: compounds 2, 3, 1 and 4 (each within the scatter of the next, the first and the last beyond it).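

Until now, swapping one small aromatic ring for another on this saturated chain carbon gave no step beyond the scatter, but pyrazin-2-yl does so, with a 3.1-fold higher number from compound 3 to compound 4 (0.49 log units; beyond the scatter) and a 3.5-fold higher number from compound 2 to compound 4 (0.55 log units; beyond the scatter), both modest. Against the thiophen-2-yl of compound 1 the change stays within the scatter, with a 2.0-fold higher number from compound 1 to compound 4 (0.30 log units; within the scatter). The position is therefore not indifferent to which ring it carries, yet nothing available here gives a reason for that.

From the compounds shown here alone, how a plain phenyl ring or a longer chain would compare at this place remains open.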